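This account rests on a few compounds, and the source may have more. Where it says the series, first, only, none or still open, it means among the compounds named here.

Compound 1 `COc1ccccc1/C=C/C(=O)/C=C/c1ccc(OCc2cn(CCCCCOc3cc(=O)oc4ccccc34)nn2)c(OC)c1` stands without a single number on this read-out: in a functional assay on PC-3 cells (Homo sapiens) for inhibition, read by sulforhodamine B assay, with a stated time of 48 h, tested at 50 uM (on this read-out lower numbers stand for less inhibition of growth and higher numbers for more inhibition of growth at the one concentration tested), compound 1 is reported as "not active" (no number reported). Compound 2 `COc1cc(/C=C/C(=O)/C=C/c2cccc3ccccc23)ccc1OCc1cn(CCCOc2cc(=O)oc3ccccc23)nn1`, which already carries naphthalen-1-yl, gives in this assay 8%. Compound 3 `COc1cc(/C=C/C(=O)/C=C/c2cccc3ccccc23)ccc1OCc1cn(CCCCCOc2cc(=O)oc3ccccc23)nn1` is not yet measured. The change from compound 1 to compound 3 is naphthalen-1-yl in place of 2-methoxyphenyl on a double-bonded chain carbon bound to a double-bonded chain carbon. Within the data shown here, no measured pair shows this step on its own; since compound 2 gives 8% with naphthalen-1-yl in place, no step beyond the scatter is expected in this assay, in either direction. Compound 3 is expected at 8%, within a range of 0% to 20%.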

Compound 3, percent growth inhibition at one concentration: "not active" (no number reported)
No number was reported for compound 3; there is nothing to compare the estimate with.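

In this assay compound 1 and compound 3 both stand without a number, so no step can be read between them. As far as these compounds go, whether naphthalen-1-yl in place of 2-methoxyphenyl alters growth inhibition stays open, and no supporting data bear on this result.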